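Swapping a pyrazole for a pyridine at the chloro-bearing ring

A few compounds are considered here, and "the series" means these few. Any claim that something is new, unique, unknown or untested is made for them only; others in the source may bear on it.

Three amides sharing one core have been measured. In an assay on C3H 10T1/2 cells for inhibition of Sonic hedgehog protein (Mus musculus), read by a luciferase reporter (a higher number here means a weaker inhibitor, a lower number a stronger inhibitor), compound 1 `Cc1nc(C(F)(F)F)ccc1C(=O)Nc1ccc(Cl)c(-c2nc3c(n2C)CCCC3)c1` gives 150 nM, compound 2 `Cc1nc(C(F)(F)F)ccc1C(=O)Nc1ccc(Cl)c(-c2cn3ccsc3n2)c1` gives 200 nM, and compound 3 `Cc1nc(C(F)(F)F)ccc1C(=O)Nc1ccc(Cl)c(-n2cccn2)c1` gives 450 nM, the highest of the three numbers. The steps of a 3.0-fold higher number from compound 1 to compound 3 (0.48 log units; beyond the scatter) and a 2.3-fold higher number from compound 2 to compound 3 (0.35 log units; beyond the scatter) both lead to compound 3 and were modest; a 1.3-fold higher number from compound 1 to compound 2 (0.12 log units; within the scatter) stayed within the scatter. Compound 4 `Cc1nc(C(F)(F)F)ccc1C(=O)Nc1ccc(Cl)c(-c2cccnc2)c1` carries pyridin-3-yl in place of 1H-pyrazol-1-yl on an aromatic carbon. Going by the values given here, no measured step covers this exact exchange; the two steps to compound 3 only show that a larger group at this position gave a lower number. A modest step toward a lower number in this assay is therefore expected, as a 1.5-fold lower number from compound 3 to compound 4 (0.18 log units; within the scatter). Compound 4 is estimated at 300 nM, with a range from 120 nM to 800 nM.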

Compound 4, half-maximal inhibitory concentration: 10000 nM
Compound 4: middle estimate off by 33-fold (1.52 log units), on the low side; measured number above the stated range.
By their numbers in this assay, from the lowest: compounds 1 and 2 (each within the scatter of the next); then compound 3; then compound 4.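

Group size alone does not order the results at this position: pyridin-3-yl has more heavy atoms than 1H-pyrazol-1-yl, yet this assay shows a 22-fold higher number from compound 3 to compound 4 (1.35 log units; beyond the scatter) and so compound 4 goes against the earlier trend. Going by these compounds alone, the gaps of a 50-fold higher number from compound 2 to compound 4 (1.70 log units; beyond the scatter) and a 67-fold higher number from compound 1 to compound 4 (1.82 log units; beyond the scatter) set the only group joined through a six-membered aromatic ring well apart from the three joined through a five-membered one. Nothing available explains this gap.

The compounds shown leave open whether ring size or nitrogen placement matters more, which phenyl, pyridin-2-yl or pyridin-4-yl could separate. From the compounds shown here alone, whether an amine on the pyridine ring would lower the number also remains unknown.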